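Chloro in place of hydrogen on a weak inhibitor

The compounds below may be only part of what the source reports. "The series", "measured", "known", "first", "only" and "open" are said of these compounds alone.

Measured in a functional assay on IGROV-1 cells (Homo sapiens) for inhibition; a lower number here means a stronger inhibitor of growth, a higher number a weaker inhibitor of growth:
Compound 1 `Cc1cc(-c2nc3c(F)cccc3s2)ccc1N`: 22900 nM
Compound 2 `Nc1ccc(-c2nc3cc(F)ccc3s2)cc1`: 11500 nM
Compound 3 `Nc1ccc(-c2nc3ccc(F)cc3s2)cc1Cl`: < 10 nM (a limit of the assay)

Compound 2 holds the lower of the two true numbers in this assay, but the gap is small: compound 1 at 22900 nM and compound 2 at 11500 nM lie within the usual scatter of each other. The only other result is a limit and not a number.

Compound 4 `Nc1ccc(-c2nc3cc(F)ccc3s2)cc1Cl` departs from compound 2 in one place: chloro in place of hydrogen on an aromatic carbon. Chloro takes the place of hydrogen on an aromatic carbon, ortho to an amino group and meta to a large group.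

Going by the values given here, no pair of measured compounds differs in a single place, so the size of this step cannot be read directly from the data. The expectation of a large step rests on compound 3 at < 10 nM, a limit of the assay, which also carries chloro ortho to an amino group. That is a single compound, and its fluoro stands in a different place from that of compound 4, so the expectation remains uncertain.

An estimated 380-fold lower number from compound 2 to compound 4 (2.58 log units; beyond the scatter) is expected, a fall in the number well beyond the scatter, meaning stronger inhibition of growth.

For compound 4 the expected value is 30 nM, with an estimated range of 3 nM to 5000 nM.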

Compound 4, concentration for 50% growth inhibition: < 10 nM
Compound 4: no number, only a limit; the forecaster's own chance of this, stated with the estimate: 45%; middle value at least 3.0-fold (0.47 log units) from the limit.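

Going by these compounds alone, until this result, the case for chloro at this position rested on compound 3 alone, whose fluoro stands in a different place. Compound 4 now gives a direct single-change comparison, and in this assay chloro in place of hydrogen, ortho to an amino group and meta to a large group, brings an at least 1100-fold lower number from compound 2 to compound 4 (3.06 log units; beyond the scatter). The printed step therefore gives only the smallest size the change can have, and the two chloro compounds, which differ only in where the fluoro stands, cannot be placed in order: the limit of < 10 nM in this assay, at which 2 of the 4 values shown sit.

The compounds shown leave open whether a different group in the same place, such as bromo, methoxy or a nitrile, would bring a comparable fall in the number, or whether the chloro itself is needed. They also leave open how far compound 3 and compound 4 reach past the limit, and whether a fluoro in any other place on the core would change the outcome of adding chloro.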